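Benzyloxy in place of prenyloxy on the cyclic sulfonate

The source may report more compounds than this note shows. Statements on the series, on what has been measured and on what is new or still open speak of the compounds shown alone.

Compounds measured so far in an ADME assay on HEL cells (Homo sapiens) for cytotoxicity, with a stated time of 3 days; a higher number here means that more compound is tolerated, a lower number that less compound is tolerated:
compound 1 `CCC1(Cc2ccccc2)OS(=O)(=O)C=C1OCc1ccccc1Cl`, compound 2 `CCC1(Cc2ccccc2)OS(=O)(=O)C=C1OCC1CCCCC1`, compound 3 `CCC1(Cc2ccccc2)OS(=O)(=O)C=C1OCC=C(C)C`.

Compound 1 gives >= 20000 nM in this assay, which is a limit and not a number. Compound 2 likewise gives only a limit, >= 200000 nM. Among the measured compounds shown here, compound 3 gives 400000 nM, the only number in the set. Consequently a step that the two limits leave unreadable from compound 1 to compound 2, a step that the limit leaves unreadable from compound 1 to compound 3 and a step that the limit leaves unreadable from compound 2 to compound 3 are all unreadable in size. Compound 4 `CCC1(Cc2ccccc2)OS(=O)(=O)C=C1OCCc1ccccc1` differs from compound 3 by benzyl in place of 2-methylprop-1-en-1-yl on a saturated chain carbon bound to an oxygen on an unsaturated carbon. No readable step bears on this change, so no direction beyond the scatter is expected. Compound 4 is therefore estimated near the value of compound 3, at 250000 nM within 60000 nM to 500000 nM, meaning an expected step of a 1.6-fold lower number from compound 3 to compound 4 (0.20 log units; within the scatter), with a fair chance that only a limit is reported.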

Compound 4, minimum cytotoxic concentration: >= 20000 nM
Compound 4 ended at the assay's limit; the forecaster's own chance of this, stated with the estimate: 45%; the middle value lies beyond the limit too.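

Compound 4 gives >= 20000 nM in this assay, a limit and not a number, so its steps from compound 1, compound 2 and compound 3 cannot be read. Going by these compounds, how benzyl ranks against 2-methylprop-1-en-1-yl, cyclohexyl and 2-chlorophenyl in tolerated concentration remains open.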